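Lengthening a Chain Ester: From Compound 3 to Compound 4

The source may hold more compounds than are shown below. What is called first, only, known or untested is meant among the compounds shown, and "the series" means these compounds.

Compound 1 `CCCCCCCCCCCCOC(=O)CCC(=O)N1CCN(CCCOc2cc3c(Nc4ccc(F)c(Cl)c4)ncnc3cc2OC)CC1`, compound 2 `CCCCCCCCCCCCCCCCCOC(=O)CCC(=O)N1CCN(CCCOc2cc3c(Nc4ccc(F)c(Cl)c4)ncnc3cc2OC)CC1` and compound 3 `CCCCCCCCCCCCCCCCCCOC(=O)CCC(=O)N1CCN(CCCOc2cc3c(Nc4ccc(F)c(Cl)c4)ncnc3cc2OC)CC1` share one core and differ only in the length of a saturated chain. In a functional assay on A549 cells (Homo sapiens) for cytotoxicity, read by MTT assay, with a stated time of 24 h, tested at 20 uM (on this read-out lower numbers stand for a stronger effect and higher numbers for a weaker effect at the one concentration tested), compound 1 gives 86.8%, compound 2 gives 97.2%, and compound 3 gives 90.5%. Compound 3 thus stands second highest of the three numbers in this assay, with compound 1 as its nearest neighbour and compound 2 the furthest, both within the scatter of it. The measured steps are a number 10.4 percentage points higher from compound 1 to compound 2 (beyond the scatter), a number 3.7 percentage points higher from compound 1 to compound 3 (within the scatter) and a number 6.7 percentage points lower from compound 2 to compound 3 (within the scatter).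

Compound 4 `CCCCCCCCCCCCCCCCCCCCOC(=O)CCC(=O)N1CCN(CCCOc2cc3c(Nc4ccc(F)c(Cl)c4)ncnc3cc2OC)CC1` extends the same chain once more: ethyl in place of hydrogen on a saturated chain carbon, ten or more bonds along the chain from an oxygen next to a carbonyl group. For the measured compounds named here, the three steps that bear on this change show that adding chain carbons at this place moved the read-out little in this assay, only one step beyond the scatter, the others within it, and with no single direction. One therefore expects for compound 4 a step of a number 1.5 percentage points higher from compound 3 to compound 4 (within the scatter) that stays within the scatter in this assay. Compound 4 is estimated at 92%, with a range from 81% to 100%.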

Compound 4, a percentage reported as activity, at one concentration (the size of the read-out at that concentration, not a potency): 90.8%
Compound 4: middle estimate off by 1.2 percentage points, on the high side, and the stated range covers the measured number.
By their numbers in this assay, from the lowest: compounds 1, 3, 4 and 2 (each within the scatter of the next, the first and the last beyond it).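

In this assay the ethyl change gives a number 0.3 percentage points higher from compound 3 to compound 4 (within the scatter), while the comparisons with the two shorter chains give a number 6.4 percentage points lower from compound 2 to compound 4 (within the scatter) and a number 4 percentage points higher from compound 1 to compound 4 (within the scatter). Compound 4 therefore lies within the scatter of all three earlier compounds, so this further extension of the chain does not separate it from any of them. Across the four compounds no steady trend with chain length appears, and the step between compound 1 and compound 2 remains the only one beyond the scatter.

As far as these compounds go, whether a chain carrying an amine or a carboxylic acid, or a chain shorter than that of compound 1, would give a read-out outside the scatter of these four remains open. Nothing shown offers a measured explanation for the similar read-outs across these chains.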